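This account rests on a few compounds, and the source may have more. Where it says the series, first, only, none or still open, it means among the compounds named here.

Three compounds sharing one core have numbers in a functional assay on MDA-MB-231 cells (Homo sapiens) for antiproliferative activity, read by MTT assay; a lower number here means a stronger inhibitor, a higher number a weaker inhibitor. Compound 1 `CCCC/C=C\CCCCCCCCCc1cc(=O)c2c(O)c(C)c(OCOC)cc2o1` gives > 87000 nM, which is a limit of the assay and not a number. Compound 2 `CCCC/C=C\CCCCCCCCCc1cc(=O)c2c(O)cc(O)cc2o1` gives 6790 nM. Compound 3 `CCCCCCCCCCCCCCCc1cc(=O)c2c(O)c(C)c(O)cc2o1`, with a saturated chain, gives 42800 nM. That places compound 3 above compound 2, and this gap lies beyond the scatter, so compound 3 is the weaker inhibitor of the two.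

Compound 4 `CCCC/C=C\CCCCCCCCCc1cc(=O)c2c(O)c(C)c(O)cc2o1` has not yet been measured. It departs from compound 3 only in the chain: hex-1-en-1-yl in place of hexyl on a saturated chain carbon, nine bonds along the chain from an aromatic carbon. Among the compounds with values here, no measured pair shows this change alone. Compound 2, at 6790 nM, carries the same unsaturated chain end but also differs from compound 3 on the core. A modest step towards a lower number is therefore expected in this assay, possibly not much beyond the scatter. The expected step is a 1.9-fold lower number from compound 3 to compound 4 (0.29 log units; within the scatter). For compound 4 the estimated value is 22000 nM, with an expected range of 8000 nM to 60000 nM.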

Compound 4, half-maximal inhibitory concentration: 42800 nM
Estimate against measurement, compound 4: 1.9-fold (0.29 log units) below; low and high end bracket the measured number.
By their numbers in this assay, from the lowest: compound 2; then compounds 3 and 4 (each within the scatter of the next). At a limit, above all of these: compound 1.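

In this assay, within the data shown here, the first direct reading of this chain change is no change at the digits printed from compound 3 to compound 4 (within the scatter), so hex-1-en-1-yl and hexyl at this place on the chain cannot be told apart here. Among these compounds, with the chain held the same, methyl in place of hydrogen on an aromatic carbon gives a 6.3-fold higher number from compound 2 to compound 4 (0.80 log units; beyond the scatter), and this is the only step with a printed size beyond the scatter. Hydrogen in place of methoxymethyl on an oxygen on an aromatic ring gives an at least 2.0-fold lower number from compound 1 to compound 4 (0.30 log units; that floor lies within the scatter), but compound 1 stands at a limit and not a number, so this is only a floor: the limit of > 87000 nM in this assay, at which 1 of the 4 values shown sits.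

From the compounds shown here alone, it remains open whether a longer chain, or an amine in place of the chain, would move the number. Going by these compounds, it is equally open whether ethyl in place of that methyl would go further than methyl does.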